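This account rests on a few compounds, and the source may have more. Where it says the series, first, only, none or still open, it means among the compounds named here.

Measured compounds:
Compound 1, `CCCCCCCCCCCCNC(=O)[C@@H](NC(=O)c1cc2ccccc2[nH]1)[C@@H](C)O` — in a functional assay on HepG2 cells (Homo sapiens) for cytotoxicity, read by MTT assay, with a stated time of 48 h (a higher number here means a weaker inhibitor, a lower number a stronger inhibitor), compound 1 gives 12000 nM.
Compound 2, `CCCCCCCCCCCCNC(=O)[C@@H](NC(=O)c1cc2ccccc2n1C)[C@@H](C)O` — compound 2 gives > 200000 nM, which is a limit of the assay and not a number.
Compound 3, `CCCCCCCCCCCCNC(=O)[C@@H](NC(=O)/C=C/c1ccccc1)[C@@H](C)O` — compound 3 gives > 200000 nM, again a limit of the assay.

Compound 2 therefore stands at the limit described by the limit of > 200000 nM in this assay, at which 2 of the 3 values shown sit, and the step of an at least 16-fold higher number from compound 1 to compound 2 (1.22 log units; beyond the scatter) shows that it is a weaker inhibitor than compound 1 by a margin beyond the scatter. The step that the two limits leave unreadable from compound 2 to compound 3 cannot be read, since both ends are limits.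

Compound 4, `CCCCCCCCCCCCCCNC(=O)[C@@H](NC(=O)c1cc2ccccc2n1C)[C@@H](C)O`, is not yet measured. It differs from compound 2 by ethyl in place of hydrogen on a saturated chain carbon, ten or more bonds along the chain from an amide-type nitrogen. Going by the values given here, none of the measured steps touches that saturated chain: they concern the methyl on the aromatic nitrogen and the group on the carbonyl carbon. Among the compounds with values here, no measured step thus bears directly on this change.

Because compound 2 sits at > 200000 nM, a limit, the expected step that the limit leaves unreadable from compound 2 to compound 4 is none beyond the scatter, with compound 4 most likely also returned as a limit. The estimate for compound 4 is 250000 nM, within the range 100000 nM to 1000000 nM.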

Compound 4, half-maximal inhibitory concentration: 34500 nM
Compound 4: the middle estimate sits 7.2-fold (0.86 log units) above what was measured; the measured number lies below the stated range.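

The saturated chain is not a silent part of these molecules: in this assay, ethyl in place of hydrogen on a saturated chain carbon, ten or more bonds along the chain from an amide-type nitrogen, gives an at least 5.7-fold lower number from compound 2 to compound 4 (0.76 log units; beyond the scatter). Going by these compounds alone, the earlier steps concerned only the methyl on the aromatic nitrogen and the group on the carbonyl carbon, so this is the first reading on the chain, and it shows that a change to the chain alone can turn a limit into a measurable number. Compound 2 gives only a limit, so this step has a lower bound and no exact size: the limit of > 200000 nM in this assay, at which 2 of the 4 values shown sit.

As far as these compounds go, whether the same ethyl change would lower the number for compound 1 or compound 3 stays open. The compounds shown also do not tell how a still longer chain, or a chain carrying an amine, would read.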